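This account rests on a few compounds, and the source may have more. Where it says the series, first, only, none or still open, it means among the compounds named here.

Compound 1 `O=C1Nc2ccccc2/C1=N/NC(=S)Nc1ccc(Br)cc1` was examined in an ADME assay on RD cells (Homo sapiens) for cytotoxicity; on this read-out higher numbers stand for lower toxicity in this test and lower numbers for higher toxicity in this test. In that test compound 1 gives only a limit, > 25000 nM, not a number. Compound 2 `O=C1Nc2ccc(Cl)cc2/C1=N/NC(=S)Nc1ccccc1` likewise gives in this assay a limit, > 25000 nM. Compound 3 `O=C1Nc2ccccc2/C1=N/NC(=S)Nc1ccc(-n2cccn2)cc1` gives in this assay a limit as well, > 25000 nM. Among the measured compounds shown here, the single step between measured neighbours, a step that the two limits leave unreadable from compound 1 to compound 3, therefore cannot be read; every value shown sits at one limit, (the limit of > 25000 nM in this assay, at which 3 of the 3 values shown sit).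

Compound 4 `Cc1ccccc1NC(=S)N/N=C1\C(=O)Nc2ccccc21` differs from compound 1 by 2-methylphenyl in place of 4-bromophenyl on an amide-type nitrogen. For the measured compounds named here, no measured step touches this change, and the one step that exists between measured compounds is unreadable, so no size or direction can be taken from the numbers. What the numbers do show is that all three measured compounds reach the limit of the test.

The expectation is that compound 4 also reaches that limit in this assay, estimated at 30000 nM with a range from 12000 nM to 90000 nM. The corresponding expected step that the limit leaves unreadable from compound 1 to compound 4 is meant as no change beyond the scatter, and it remains only an estimate.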

Compound 4, half-maximal cytotoxic concentration: > 25000 nM
Compound 4 was reported as a limit; the forecaster's own chance of this, stated with the estimate: 85%; the middle value lies beyond the limit too.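

In this assay, among the compounds shown here, compound 4 and compound 1 both give only a limit, so no step between them can be read. The compounds shown leave open the concentration at which any of them becomes cytotoxic to these cells, since all sit at one limit: the limit of > 25000 nM in this assay, at which 4 of the 4 values shown sit.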